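A few compounds are considered here, and "the series" means these few. Any claim that something is new, unique, unknown or untested is made for them only; others in the source may bear on it.

Compound 1 `COC1Cc2c(csc2-c2ccc(C)cc2)C2(CCN(Cc3ccccc3)CC2)O1` in an assay on membranes from brain for displacement of a labelled ligand from Sigma non-opioid intracellular receptor 1 (Cavia porcellus), read by scintillation counting, with a stated time of 120 min (on this read-out lower numbers stand for stronger inhibition and higher numbers for weaker inhibition), gives 2 nM.
Compound 2 `COC1Cc2c(csc2-c2ccc([N+](=O)[O-])cc2)C2(CCN(Cc3ccccc3)CC2)O1` in this assay gives 1 nM.

Of the compounds shown here, two have been measured, and they share the same core; they differ only in the group on the outer aromatic ring. Compound 2 shows the lower of the two numbers, but the step from compound 1 to compound 2 is a 2.0-fold lower number from compound 1 to compound 2 (0.30 log units; within the scatter), so the two values sit within the usual scatter and neither can be called stronger.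

Compound 3 `COC1Cc2c(csc2-c2ccc(C#N)cc2)C2(CCN(Cc3ccccc3)CC2)O1` carries the change (cyano in place of nitro on an aromatic carbon). Within the data shown here, the only measured step that bears on this position, that from compound 1 to compound 2, was a 2.0-fold lower number from compound 1 to compound 2 (0.30 log units; within the scatter); swapping one group for another at this place has so far moved the number by no more than the scatter. On that basis no step beyond the scatter is expected in this assay. Compound 3 is therefore estimated to give about 1.5 nM, with a range from 0.5 nM to 5 nM. This expectation amounts to a 1.5-fold higher number from compound 2 to compound 3 (0.18 log units; within the scatter).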

Compound 3, inhibition constant: 0.25 nM
Compound 3: middle estimate off by 6.0-fold (0.78 log units), on the high side, and the stated range ends above it.
By their numbers in this assay, from the lowest: compound 3; then compounds 2 and 1 (each within the scatter of the next).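

This position is less indifferent to its group than the first pair suggested: in this assay cyano gives a 4.0-fold lower number from compound 2 to compound 3 (0.60 log units; beyond the scatter) and also an 8.0-fold lower number from compound 1 to compound 3 (0.90 log units; beyond the scatter) and so separates from both earlier groups. Methyl and nitro remain within the scatter of each other, so compound 3 alone stands apart, and of these three compounds it is the strongest on this read-out. Nothing measured here gives a reason for this difference.

Only methyl, nitro and cyano are shown at this place, so it remains open how an amine, a carboxylic acid or a chlorine atom would fare there. Going by these compounds, it is also open whether cyano would give a similar step on another carbon of the same aromatic ring.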